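This account rests on a few compounds, and the source may have more. Where it says the series, first, only, none or still open, it means among the compounds named here.

Compound 1, `CC(=O)N1CC2CC(C1)N2`, gives 9700 nM in an assay on SH-EP1 cells for agonist activity at Neuronal acetylcholine receptor; alpha4/beta2 (Homo sapiens), read by FLIPR and calcium flux; a lower number here means that less compound is needed, a higher number that more compound is needed for the effect.
Compound 2, `O=C(C1CCC1)N1CC2CC(C1)N2`, gives 11000 nM in this assay.
Compound 3, `O=C([C@@H]1C[C@@H]1F)N1CC2CC(C1)N2`, gives 370 nM in this assay.

Compound 1 stands second highest of these three numbers, close to compound 2 and far from compound 3. The step to compound 4, `O=C([C@H]1C[C@@H]1F)N1CC2CC(C1)N2`, is 2-fluorocyclopropyl in place of methyl on a carbonyl carbon. Compound 4 carries the same group as compound 3, but its two defined stereocentres are set differently. Among the measured compounds shown here, two measured steps bear on this change. Replacing methyl with cyclobutyl, a 1.1-fold higher number from compound 1 to compound 2 (0.05 log units; within the scatter), did nothing beyond the scatter. Replacing methyl with the 2-fluorocyclopropyl of compound 3, a 26-fold lower number from compound 1 to compound 3 (1.42 log units; beyond the scatter), gave a large drop in the number needed, as did a 30-fold lower number from compound 2 to compound 3 (1.47 log units; beyond the scatter). Nothing here shows how the alternative setting of the stereocentres in compound 4 behaves, so the size of its step is uncertain. Compound 4 is therefore expected to show a lower number than compound 1 in this assay, by a step of a 6.5-fold lower number from compound 1 to compound 4 (0.81 log units; beyond the scatter), but smaller than that of compound 3. The estimate for compound 4 is 1500 nM, within a range from 300 nM to 8000 nM.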

Compound 4, half-maximal effective concentration: 2800 nM
Beside the measured number, compound 4's estimate is 1.9-fold (0.27 log units) below it, within the range that was stated.
By their numbers in this assay, from the lowest: compound 3; then compound 4; then compounds 1 and 2 (each within the scatter of the next).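

With atoms and bonds unchanged, a stereocentre at a saturated ring carbon drawn R rather than S gives a 7.6-fold higher number from compound 3 to compound 4 (0.88 log units; beyond the scatter) in this assay, so the spatial arrangement of the 2-fluorocyclopropyl matters, not only its presence. Even this weaker arrangement keeps a gain over methyl, a 3.5-fold lower number from compound 1 to compound 4 (0.54 log units; beyond the scatter), and over cyclobutyl, a 3.9-fold lower number from compound 2 to compound 4 (0.59 log units; beyond the scatter), so both stereo forms shown of the group give lower numbers than those two groups. One caution applies to reading the gap as a clean stereo effect: the fact that one of compounds 3 and 4 is drawn with a defined configuration and the other without, at the place where they differ.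

The compounds shown leave open how much of the gain belongs to the fluorine and how much to the three-membered ring, a question that a plain cyclopropyl on the carbonyl carbon would address. From the compounds shown here alone, how a 2-chlorocyclopropyl or a longer chain would behave in this place also remains open.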